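Swapping chloro for amino on a fused chlorinated core

The source may hold more compounds than are shown below. What is called first, only, known or untested is meant among the compounds shown, and "the series" means these compounds.

Three related compounds have been tested for their ability to stop the growth of lung tumour cells. In a functional assay on A549 cells (Homo sapiens) for cytotoxicity, read by sulforhodamine B assay, with a stated time of 48 h (on this read-out lower numbers stand for stronger inhibition of growth and higher numbers for weaker inhibition of growth), compound 1, with the structure `ClCc1ccccc1Cn1cnc2c(Cl)nc(Cl)nc21`, gives 4670 nM. Compound 2, with the structure `ClCc1cccc(Cn2cnc3c(Cl)nc(Cl)nc32)c1`, shares the same atoms joined in a different arrangement, and the difference between the two cores is not broken down here; in this assay compound 2 gives 10000 nM. Compound 3, with the structure `Nc1nc(Cl)c2ncn(Cc3ccccc3CCl)c2n1`, differs from compound 1 by a single change, (amino in place of chloro on an aromatic carbon), and in this assay compound 3 gives 53700 nM. That change brought an 11-fold higher number from compound 1 to compound 3 (1.06 log units; beyond the scatter), a clear weakening of growth inhibition.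

Compound 4, with the structure `Nc1nc(Cl)c2ncn(Cc3cccc(CCl)c3)c2n1`, has not yet been measured. It stands to compound 2 as compound 3 stands to compound 1: the change is amino in place of chloro on an aromatic carbon, the same change as before, occurring twice among these compounds.

For the measured compounds named here, because an 11-fold higher number from compound 1 to compound 3 (1.06 log units; beyond the scatter) was large and well beyond the scatter, a step of comparable size is expected from compound 2 to compound 4, namely a 10-fold higher number from compound 2 to compound 4 (1.00 log units; beyond the scatter), though with only one prior example the size is uncertain. Compound 4 is therefore estimated to give 100000 nM, likely between 35000 nM and 300000 nM.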

Compound 4, concentration for total growth inhibition: 27500 nM
Compound 4: middle estimate off by 3.6-fold (0.56 log units), on the high side; measured number outside the range, below it.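

In this assay, putting amino in place of chloro weakened growth inhibition on both cores, and on the second core it gave a 2.8-fold higher number from compound 2 to compound 4 (0.44 log units; beyond the scatter). The direction of the change therefore carried over from one core to the other, but its size did not: the same change on two cores in this assay, an 11-fold higher number (1.06 log units; beyond the scatter) from compound 1 to compound 3 and a 2.8-fold higher number (0.44 log units; beyond the scatter) from compound 2 to compound 4, 4.2-fold (0.62 log units) apart, beyond the scatter of two such steps. These two pairs do not show why the size differs, only that the arrangement of atoms separating compound 1 from compound 2 goes along with a different step, so a step measured on one core in this series is a poor guide to the exact size of the step on the other, and two pairs are too few to establish a general rule.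

The compounds shown leave open whether another group in the same place, such as methoxy, hydroxyl or methylamino, would weaken growth inhibition as amino does, or by a similar amount on both cores. They also leave open what would happen if the chloromethyl group were replaced, for example by a methyl or a hydroxymethyl group, and whether the step seen for amino would then stay the same.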